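Sulfonyl aryl variation across three measured compounds and one pending

The source may hold more compounds than are shown below. What is called first, only, known or untested is meant among the compounds shown, and "the series" means these compounds.

Three compounds share one core and differ only in the aryl group carried on the sulfonyl sulfur. Compound 1 `CC1CCN(c2c(S(=O)(=O)c3cccc(C#N)c3)cnc3cc(F)ccc23)CC1` gives 92% in an assay on isolated protein for displacement of a labelled ligand from metabotropic glutamate receptor 5 (Homo sapiens), with a stated time of 60 min, tested at 1 uM; a higher number here means more inhibition at the concentration tested (going by the name of the read-out), a lower number less inhibition. Compound 2 `CC1CCN(c2c(S(=O)(=O)c3ccc(C#N)cc3)cnc3cc(F)ccc23)CC1` gives 83% in this assay, and compound 3 `CC1CCN(c2c(S(=O)(=O)c3ccc(F)c(F)c3)cnc3cc(F)ccc23)CC1` gives 94% in this assay. Compound 3 holds the highest of the three numbers; its gap to compound 1 lies within the scatter, its gap to compound 2 beyond it. The steps seen so far are a number 9 percentage points lower from compound 1 to compound 2 (within the scatter), a number 2 percentage points higher from compound 1 to compound 3 (within the scatter) and a number 11 percentage points higher from compound 2 to compound 3 (beyond the scatter).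

Compound 4 `Cc1ccc(S(=O)(=O)c2cnc3cc(F)ccc3c2N2CCC(C)CC2)cc1` has not yet been measured. Against compound 3 the change is 4-methylphenyl in place of 3,4-difluorophenyl on a sulfonyl sulfur. Every measured step exchanges the aryl on the sulfonyl sulfur, and none of them moved the number by more than a modest amount, so a step of the same kind is expected here: at most a small drop, possibly nothing beyond the scatter, which is the expected a number 9 percentage points lower from compound 3 to compound 4 (within the scatter). Compound 4 is therefore expected to give about 85% in this assay, with a range from 70% to 95%.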

Compound 4, a percentage reported as inhibition, at one concentration (the size of the read-out at that concentration, not a potency): 88%
For compound 4 the middle estimate is 3 percentage points below the measured one; the range from low to high includes it.
By their numbers in this assay, from the lowest: compounds 2, 4, 1 and 3 (each within the scatter of the next, the first and the last beyond it).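

The 4-methylphenyl group on the sulfonyl sulfur brings an aryl with only carbon among its heavy atoms, and in this assay it gives a number 6 percentage points lower from compound 3 to compound 4 (within the scatter), a number 4 percentage points lower from compound 1 to compound 4 (within the scatter) and a number 5 percentage points higher from compound 2 to compound 4 (within the scatter). At this position, then, neither fluorine nor a nitrile on the aryl is required across these four compounds for the number to stay in this range, and methyl in place of cyano makes no step beyond the scatter. Nothing available on these compounds explains these steps.

Still open, as far as these compounds go, is whether the number holds with a carboxylic acid or an amine on the phenyl ring, or with a longer alkyl chain in place of the aryl. With one concentration as the only read-out, the relative potency of these four compounds also remains unresolved.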